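Anilide substituent variation on the bis-benzylidene series

The compounds below may be only part of what the source reports. "The series", "measured", "known", "first", "only" and "open" are said of these compounds alone.

Of the compounds shown here, three have been measured in a functional assay on CCRF-CEM cells (Homo sapiens) for cytotoxicity; a higher number here means a weaker inhibitor, a lower number a stronger inhibitor. Compound 1 `Cc1ccc(NC(=O)/C=C/C(=O)N2C/C(=C\c3ccc([N+](=O)[O-])cc3)C(=O)/C(=C/c3ccc([N+](=O)[O-])cc3)C2)cc1` gives 890 nM. Compound 2 `COc1ccc(NC(=O)/C=C/C(=O)N2C/C(=C\c3ccccc3)C(=O)/C(=C/c3ccccc3)C2)cc1` gives 510 nM, and compound 3 `O=C(/C=C/C(=O)N1C/C(=C\c2ccccc2)C(=O)/C(=C/c2ccccc2)C1)Nc1ccc(Cl)cc1` gives 840 nM. Compound 1 holds the highest of the three numbers, yet all three fall within the scatter of one another. Among the compounds with values here, the one step between measured compounds that differ in one place, a 1.6-fold higher number from compound 2 to compound 3 (0.22 log units; within the scatter), concerns the same aromatic carbon of the anilide ring that changes here. Compound 4 `O=C(/C=C/C(=O)N1C/C(=C\c2ccc([N+](=O)[O-])cc2)C(=O)/C(=C/c2ccc([N+](=O)[O-])cc2)C1)Nc1ccccc1` differs from compound 1 by hydrogen in place of methyl on an aromatic carbon. Since swapping groups at that position left the number within the scatter, no step beyond the scatter is expected for a 1.0-fold higher number from compound 1 to compound 4 (0.00 log units; within the scatter). Compound 4 is therefore estimated at 900 nM, with a range from 450 nM to 1800 nM.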

Compound 4, half-maximal inhibitory concentration: 370 nM
For compound 4 the middle estimate is 2.4-fold (0.39 log units) above the measured one; measured number below the stated range.
By their numbers in this assay, from the lowest: compounds 4, 2, 3 and 1 (each within the scatter of the next, the first and the last beyond it).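

In this assay, the change from 4-methylphenyl to phenyl gives a 2.4-fold lower number from compound 1 to compound 4 (0.38 log units; beyond the scatter), so this carbon, para to a large group, does respond, though modestly, unlike the chloro-for-methoxy swap at a 1.6-fold higher number from compound 2 to compound 3 (0.22 log units; within the scatter). The two steps sit on different cores, so they make no rule for the position. Nothing at hand bears on why the number moves.

Open, going by these compounds, is whether the same hydrogen-for-methyl change gives a step on the core of compound 2. Also open, on these data alone, is how an amine or a carboxylic acid at this carbon would read.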